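Working notes: from compound 2 to compound 4

A few compounds are considered here, and "the series" means these few. Any claim that something is new, unique, unknown or untested is made for them only; others in the source may bear on it.

Measured so far in an ADME assay on microsomes from liver (Mus musculus) for metabolic stability, read by LC-MS, with a stated time of 10 min (on this read-out lower numbers stand for a less stable compound and higher numbers for a more stable compound), as follows
- compound 1 `C[C@@H]1CN(c2cccc3c2C[C@H](CN(C)[C@H]2CCCc4cccnc42)NC3)C[C@H](C)N1` gives 85.6%
- compound 2 `CN(C[C@H]1Cc2c(cccc2N2CCN(C3CC3)CC2)CN1)[C@H]1CCCc2cccnc21` gives 7%
- compound 3 `CN(C[C@H]1Cc2c(cccc2N2CCNC(C)(C)C2)CN1)[C@H]1CCCc2cccnc21` gives 44%

Compound 2 stands lowest of the three, with compound 3 nearest and compound 1 furthest, both beyond the scatter. Compound 4 `CN(C[C@H]1Cc2c(cccc2N2CCN(Cc3ccccn3)CC2)CN1)[C@H]1CCCc2cccnc21` is still unmeasured. Relative to compound 2 it shows (pyridin-2-yl)methyl in place of cyclopropyl on an amine nitrogen in a ring and so carries (pyridin-2-yl)methyl in place of cyclopropyl on an amine nitrogen in a ring.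

Going by the values given here, no measured step swaps one substituent on that nitrogen for another. The closest evidence is a number 78.6 percentage points lower from compound 1 to compound 2 (beyond the scatter) and a number 37 percentage points higher from compound 2 to compound 3 (beyond the scatter) (both large), and each sets compound 2 against a compound with no substituent there. Since compound 4 keeps a substituent there, these steps give only indirect guidance from a single example. Compound 2 at 7% also leaves little room downward. No step beyond the scatter is expected, so the estimate is a number 2 percentage points higher from compound 2 to compound 4 (within the scatter) in this series. Compound 4 is expected at 9% with an estimated range of 2% to 25% in this assay once measured.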

Compound 4, percent of the compound remaining: 40.4%
For compound 4 the middle estimate is 31.4 percentage points below the measured one; measured number above the stated range.
By their numbers in this assay, from the lowest: compound 2; then compounds 4 and 3 (each within the scatter of the next); then compound 1.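

Going by these compounds alone, this is the first measured exchange of one substituent for another on the amine nitrogen in a ring, and in this assay it gives a number 33.4 percentage points higher from compound 2 to compound 4 (beyond the scatter). The low read-out of compound 2 therefore does not follow from having a substituent on that nitrogen alone, since the identity of the substituent matters here: cyclopropyl and (pyridin-2-yl)methyl are clearly apart. Nothing at hand bears on why these two groups differ.

The compounds shown leave open whether the difference depends on the nitrogen in the aromatic ring of (pyridin-2-yl)methyl or on the aromatic ring as such. A benzyl group on the same nitrogen would separate these two readings, and a simple methyl group would show how much of the difference needs any ring at all.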